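A few compounds are considered here, and "the series" means these few. Any claim that something is new, unique, unknown or untested is made for them only; others in the source may bear on it.

Measured in an ADME assay on Vero cells (Chlorocebus sabaeus) for cytotoxicity, read by resazurin assay, with a stated time of 72 h; on this read-out lower numbers stand for higher toxicity in this test and higher numbers for lower toxicity in this test:
Compound 1 `CO[C@@]1(C)OOC(c2ccc(F)cc2)(c2ccc(F)cc2)C[C@H]1CNCCCn1ccnc1`: 93600 nM
Compound 2 `COC(=O)C1CC(c2ccccc2)(c2ccccc2)OOC1(C)OC`: "not determined" (no result reported)
Compound 3 `CCCC[C@]1(OC)OOC(c2ccccc2)(c2ccccc2)C[C@H]1CNCCCn1ccnc1`: 9500 nM

Among the measured compounds shown here, only two of these three compounds have a number. Compound 3, at 9500 nM, holds the lower of the two, and compound 1, at 93600 nM, stands higher by a gap beyond the usual scatter. Compound 2 offers no comparison, its entry reading "not determined" (no result reported).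

The next compound in the series is compound 4 `CO[C@@]1(C)OOC(c2ccccc2)(c2ccccc2)C[C@H]1CNCCCn1ccnc1`, which has not yet been measured in this assay. Going from compound 3 to compound 4, the structure changes as follows: hydrogen in place of propyl on a saturated chain carbon bound to a saturated ring carbon. Cut one bond further out, the same difference reads butyl to methyl.

For the measured compounds named here, no measured pair isolates this change, so the expectation rests on indirect evidence. Compound 1 has the methyl form of this chain, though it also carries fluorine on its phenyl groups, and it gives 93600 nM. A sizeable upward step, beyond the scatter, therefore seems likely, pointing towards lower toxicity in this test. The expected change is a 5.3-fold higher number from compound 3 to compound 4 (0.72 log units; beyond the scatter). For compound 4 the estimated value is 50000 nM, with an expected range from 18000 nM to 130000 nM.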

Compound 4, half-maximal cytotoxic concentration: 50000 nM
Beside the measured number, compound 4's estimate shows no gap at the digits printed; the measured number falls inside the stated range.
By their numbers in this assay, from the lowest: compound 3; then compounds 4 and 1 (each within the scatter of the next).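

In this assay, among the compounds shown here, the exchange of butyl for methyl on a saturated ring carbon gives a 5.3-fold higher number from compound 3 to compound 4 (0.72 log units; beyond the scatter) and so provides the first direct reading of this position, as no earlier pair of measured compounds differed in one place only. With the rest of the structure unchanged, the shorter group goes with the higher number, which on this read-out stands for lower toxicity in this test. Nothing measured here accounts for this shift.

With only the butyl and methyl forms of this chain compared directly, the compounds shown leave open how the number behaves with ethyl or propyl, with a longer chain such as hexyl, or with a ring such as cyclopropyl in the same place. They also leave open whether an amine or a carboxylic acid on this chain would move the number in the same direction, and whether the same exchange would give a step of similar size with the fluorine-bearing phenyl groups of compound 1.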